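This account rests on a few compounds, and the source may have more. Where it says the series, first, only, none or still open, it means among the compounds named here.

In a functional assay on the whole organism with Rattus norvegicus as the target (on this read-out higher numbers stand for an effect only at larger amounts of compound and lower numbers for an effect already at smaller amounts), compound 1 `CC(C)(C)c1ccc2nc(N)sc2c1` gives 4 mg/kg as its reading. Compound 2 `Nc1nc2ccc(C(=O)C(F)(F)F)cc2s1` reads > 10 mg/kg and that is a limit of the assay, not a number. Compound 3 `CCCCn1c(=N)sc2cc(OC(F)(F)F)ccc21` gives 10 mg/kg as the higher of the two true numbers, and its gap to compound 1 lies beyond the usual scatter.

Compound 4 `CCN(CC)C(=O)Cn1c(=N)sc2cc(OC(F)(F)F)ccc21` has not been measured yet. It differs from compound 3 in one place, with diethylcarbamoyl in place of propyl on a saturated chain carbon bound to an aromatic nitrogen. The count of that change is diethylcarbamoyl in place of propyl on a saturated chain carbon bound to an aromatic nitrogen and it adds a larger side chain with a carbonyl. Among the measured compounds shown here, no two measured compounds differ in one place only, so nothing here shows directly what such a swap does.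

The expectation therefore starts from compound 3 at 10 mg/kg and foresees no shift beyond the usual scatter. The estimated step of a 1.3-fold lower number from compound 3 to compound 4 (0.10 log units; within the scatter) is small and points to a slightly lower number. For compound 4 the estimated dose is 8 mg/kg with an expected range from 3 mg/kg to 15 mg/kg in this test.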

Compound 4, dose for half-maximal effect: 9 mg/kg
Compound 4: the middle estimate sits 1.1-fold (0.05 log units) below what was measured; low and high end bracket the measured number.
By their numbers in this assay, from the lowest: compound 1; then compounds 4 and 3 (each within the scatter of the next).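

Among the compounds shown here, the first pair of compounds that differ in one place shows, in this assay, a 1.1-fold lower number from compound 3 to compound 4 (0.05 log units; within the scatter). At this position, on a saturated chain carbon bound to an aromatic nitrogen, diethylcarbamoyl in place of propyl brings a larger side chain with a carbonyl and a hydrogen-bond acceptor, yet the two readings cannot be told apart. Compound 2 gives a limit and not a number, so it adds no further reading to set beside this pair: the limit of > 10 mg/kg in this assay, at which 1 of the 4 values shown sits.

This single swap does not tell whether an amine, a carboxylic acid or a much longer chain on the same chain carbon would read differently. On these data alone, whether diethylcarbamoyl and propyl would also read alike with another group elsewhere on the shared core stays open as well.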